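Replacing methoxy with bromo on a weakly active compound

A few compounds are considered here, and "the series" means these few. Any claim that something is new, unique, unknown or untested is made for them only; others in the source may bear on it.

Measured in a functional assay on QG-56 cells (Homo sapiens) for antiproliferative activity; a higher number here means a weaker inhibitor, a lower number a stronger inhibitor:
- compound 1 `COc1cccc(-c2cc([N+](=O)[O-])cc3cc(C(O)(c4ccc(C#N)cc4)c4cncn4C)oc23)c1`: 38.8 nM
- compound 2 `COc1ccc(C(O)(c2cc3cc([N+](=O)[O-])cc(-c4ccccc4)c3o2)c2cncn2C)cc1`: 4970 nM
- compound 3 `COc1cccc(-c2cc(CO)cc3cc(C(O)(c4ccc(C#N)cc4)c4cncn4C)oc23)c1`: 16.8 nM

Compound 2 has the highest number of the three, well beyond the scatter from both others. Compound 4 `Cn1cncc1C(O)(c1ccc(Br)cc1)c1cc2cc([N+](=O)[O-])cc(-c3ccccc3)c2o1` changes it in one place: bromo in place of methoxy on an aromatic carbon. Among the measured compounds shown here, no measured step touches this group. For the measured compounds named here, the only step available, a 2.3-fold lower number from compound 1 to compound 3 (0.36 log units; beyond the scatter), exchanges a different group, so it offers little guidance. Compounds 1 and 3 differ from compound 2 in more than one place, so their much lower numbers cannot be assigned to any single group. A modest drop in this assay is expected, with wide uncertainty. The expected change is a 2.0-fold lower number from compound 2 to compound 4 (0.30 log units; within the scatter). Compound 4 is estimated at 2500 nM, with an expected range from 500 nM to 10000 nM.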

Compound 4, half-maximal inhibitory concentration: 1480 nM
Compound 4: middle estimate off by 1.7-fold (0.23 log units), on the high side; the range from low to high includes it.
By their numbers in this assay, from the lowest: compound 3; then compound 1; then compound 4; then compound 2.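

Going from 4-methoxyphenyl to 4-bromophenyl gives the first measured step at this position. In this assay, the result is a 3.4-fold lower number from compound 2 to compound 4 (0.53 log units; beyond the scatter), so this single exchange moves the number by more than the scatter, though only modestly. No available measurement explains why the number falls.

The compounds shown do not tell whether fluoro, chloro or an amine in the same place would lower the number further. They also leave open whether bromo would give a similar step with other groups elsewhere on the core.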